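Chloro for fluoro on two different rings

This account rests on a few compounds, and the source may have more. Where it says the series, first, only, none or still open, it means among the compounds named here.

Compound 1 `O=C(NC(c1ccc(F)c(F)c1)C1CCNCC1)c1ccc2cnccc2c1` carries two fluoro groups on its phenyl ring. In an assay on isolated protein for inhibition of RAC-alpha serine/threonine-protein kinase (Homo sapiens) (a lower number here means a stronger inhibitor, a higher number a weaker inhibitor), compound 1 gives 2680 nM. Compound 2 `O=C(NC(c1ccc(Cl)c(F)c1)C1CCNCC1)c1ccc2cnccc2c1` differs in one place, (chloro in place of fluoro on an aromatic carbon), and in this assay compound 2 gives 40 nM. That single swap made a 67-fold lower number from compound 1 to compound 2 (1.83 log units; beyond the scatter).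

Compound 3 `O=C(NC(c1ccc(Cl)c(Cl)c1)C1CCNCC1)c1ccc2cnc(F)cc2c1` has a different core; how its core differs from that of compound 1 is not broken down here. In this assay compound 3 gives 20 nM, a number that lies within the usual scatter of that of compound 2, so the two cannot be ranked against each other.

Compound 4 `O=C(NC(c1ccc(Cl)c(Cl)c1)C1CCNCC1)c1ccc2cnc(Cl)cc2c1` has not yet been measured. It differs from compound 3 in one place, (chloro in place of fluoro on an aromatic carbon). This is the same kind of change as that from compound 1 to compound 2, but not the same: the earlier swap sat on a six-membered aromatic ring of carbon only, ortho to a fluoro group and para to a large group, whereas here it sits on a six-membered aromatic ring with one nitrogen, part of a fused system of two rings, next to the ring nitrogen. The large gain seen from compound 1 to compound 2 therefore need not carry over. For compound 4 a step of a 1.3-fold lower number from compound 3 to compound 4 (0.12 log units; within the scatter) is expected in this assay, a modest change that rests on compound 3 giving 20 nM and on the swap sitting on a different ring. Compound 4 is thus estimated at 15 nM, with a likely range from 5 nM to 60 nM.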

Compound 4, half-maximal inhibitory concentration: 140 nM
Beside the measured number, compound 4's estimate is 9.3-fold (0.97 log units) below it; the measured number lies above the stated range.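

In this assay, putting chloro in place of fluoro on an aromatic carbon of the ring with one nitrogen gave a 7.0-fold higher number from compound 3 to compound 4 (0.85 log units; beyond the scatter), so here the swap weakened the inhibitor, whereas the earlier swap on the phenyl ring strengthened it. The same kind of change therefore has no fixed effect in this series, and a gain seen on one core cannot simply be assumed on another: the same change on two cores in this assay, a 67-fold lower number (1.83 log units; beyond the scatter) from compound 1 to compound 2 and a 7.0-fold higher number (0.85 log units; beyond the scatter) from compound 3 to compound 4, 470-fold (2.67 log units) apart, beyond the scatter of two such steps. What this does not show is why the two steps differ, since the swap sits on a different ring in each pair and the rest of the molecule differs as well, so two pairs can neither separate these factors nor give a general rule.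

Still open, going by these compounds, is how the same swap would behave on the phenyl ring of a compound that otherwise matches compound 3, which would test the ring and the remaining structure separately. On these data alone, it is also open how a methyl group or an amine would compare with fluoro and chloro on the aromatic carbon next to the ring nitrogen, and whether the result there depends on the size of the group or on something else.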